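A Smaller Substituent on the Carbonyl Carbon

A few compounds are considered here, and "the series" means these few. Any claim that something is new, unique, unknown or untested is made for them only; others in the source may bear on it.

Compound 2 `COC(=O)CCNC(=O)[C@@H]1O[P@@](=O)(OCOC(=O)c2cc(C(C)(C)C)n[nH]2)OCC1(C)C` is the starting point of this account. In an ADME assay on blood (Homo sapiens) for pharmacokinetics (a higher number here means that the compound lasts longer, a lower number that the compound disappears faster), compound 2 gives only a limit of the assay, > 1 h. Compound 1 `COC(=O)CCNC(=O)[C@@H]1O[P@@](=O)(OCOC(=O)c2ccnn2C)OCC1(C)C` differs from compound 2 in one place, the group on the carbonyl carbon. Compound 1 likewise reaches a limit, > 1 h. The step that the two limits leave unreadable from compound 1 to compound 2 therefore cannot be sized. Compound 3 `CC(C)(C)C(=O)OCO[P@@]1(=O)OCC(C)(C)[C@H](C(=O)NCCC(=O)OCCc2ccccn2)O1` sits at the other limit of this assay, < 0.16 h. Two of the three values thus stand at the limit of > 1 h in this assay, at which 2 of the 3 values shown sit, and one at the limit of < 0.16 h in this assay, at which 1 of the 3 values shown sits.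

Compound 4 `COC(=O)CCNC(=O)[C@@H]1O[P@@](=O)(OCOC(=O)c2cc(C)nn2C)OCC1(C)C` carries the change (1,3-dimethyl-1H-pyrazol-5-yl in place of 3-(tert-butyl)-1H-pyrazol-5-yl on a carbonyl carbon). Going by the values given here, the only measured single-place step that touches this position is the one from compound 1 to compound 2, and its size is unreadable; no step beyond the scatter is readable in either direction. Compound 4 is therefore expected to reach the same limit as compound 2, and the step that the limit leaves unreadable from compound 2 to compound 4 is estimated to lie within the scatter. Compound 4 is estimated at 2 h, within 0.8 h to 6 h, and will most likely be reported again only as a limit.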

Compound 4, half-life: > 1 h
Compound 4: no number, only a limit; the forecaster's own chance of this, stated with the estimate: 75%; the middle value is on the limit's open side.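

In this assay compound 4 gives only a limit, > 1 h. Compound 1 and compound 2 stand at that same limit, so no step among these three compounds can be read. The compounds shown leave open how long each of the three actually lasts, and whether the group on the carbonyl carbon makes any difference.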